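Swapping 3,5-dimethoxyphenyl for 3-hydroxyphenyl: notes on compound 3

The source may hold more compounds than are shown below. What is called first, only, known or untested is meant among the compounds shown, and "the series" means these compounds.

In a functional assay on K562 cells (Homo sapiens) for inhibition, read by fluorescence, with a stated time of 72 h (on this read-out lower numbers stand for stronger inhibition of growth and higher numbers for weaker inhibition of growth), compound 1 `CC(C)CCn1cnc2c(Nc3ccc(Cl)cc3)nc(N[C@H]3CC[C@H](N)CC3)nc21` gives 1800 nM and compound 2 `COc1cc(Nc2nc(N[C@H]3CC[C@H](N)CC3)nc3c2ncn3CCC(C)C)cc(OC)c1` gives 2500 nM. Among the measured compounds shown here, the only measured step, a 1.4-fold higher number from compound 1 to compound 2 (0.14 log units; within the scatter), lies within the scatter, so compound 2 stands level with compound 1 on these numbers.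

Next is compound 3 `CC(C)CCn1cnc2c(Nc3cccc(O)c3)nc(N[C@H]3CC[C@H](N)CC3)nc21`, which carries 3-hydroxyphenyl in place of 3,5-dimethoxyphenyl on a nitrogen on an aromatic ring. For the measured compounds named here, no measured compound yet carries this group, so the only guide is the earlier change at the same place. Given a 1.4-fold higher number from compound 1 to compound 2 (0.14 log units; within the scatter), no step beyond the scatter is expected in this assay, and no direction can be argued from two compounds. The expected step is a 1.3-fold lower number from compound 2 to compound 3 (0.10 log units; within the scatter). For compound 3 the estimated value is 2000 nM. The expected range for compound 3 runs from 700 nM to 5500 nM.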

Compound 3, concentration for 50% growth inhibition: 7600 nM
Compound 3: the middle estimate sits 3.8-fold (0.58 log units) below what was measured; measured number outside the range, above it.
By their numbers in this assay, from the lowest: compounds 1 and 2 (each within the scatter of the next); then compound 3.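

In this assay the group on a nitrogen on an aromatic ring now separates the compounds: a 3.0-fold higher number from compound 2 to compound 3 (0.48 log units; beyond the scatter) and a 4.2-fold higher number from compound 1 to compound 3 (0.63 log units; beyond the scatter) both lie beyond the scatter, so this place is not indifferent to the group it carries. Of the three groups shown, 3-hydroxyphenyl goes with the highest number and is the only one with a hydrogen-bond donor, but these compounds cannot separate the entering hydroxyl from the loss of the two methoxy groups or of the chlorine. No measurement shown here accounts for the step.

Going by these compounds, it remains open whether 3-methoxyphenyl or 3-aminophenyl would follow compound 3 or stay level with compound 1 and compound 2. Also open, on these data alone, is whether the step persists with a longer chain in place of the one shared by all three compounds.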